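Methyl on the core ring: compound 2 to compound 4

The source may report more compounds than this note shows. Statements on the series, on what has been measured and on what is new or still open speak of the compounds shown alone.

Compound 2 `COCCc1ccc(Oc2ccnc(Nc3ccc(C#N)cc3)n2)cc1` gives 93300 nM in an ADME assay on MT4 cells (Homo sapiens) for cytotoxicity, read by MTT assay, with a stated time of 5 days (a lower number here means that less compound is tolerated, a higher number that more compound is tolerated), the highest of the two numbers shown; its nearest neighbour, compound 3 `COc1ccc(C(=O)c2ccccc2)c(Oc2cc(C)nc(Nc3ccc(C#N)cc3)n2)c1`, gives 4900 nM, a gap beyond the scatter. Compound 1 `N#Cc1ccc(Nc2nccc(Oc3ccc(OCc4ccccc4)cc3)n2)cc1` reaches only a limit, > 316000 nM, in this assay. Among the measured compounds shown here, the single measured step, an at least 3.3-fold lower number from compound 1 to compound 2 (0.52 log units; beyond the scatter), alters a different part of the molecule and does not bear on the present change. Compound 4 `COCCc1ccc(Oc2cc(C)nc(Nc3ccc(C#N)cc3)n2)cc1` differs from compound 2 by methyl in place of hydrogen on an aromatic carbon. Compound 3 carries the same methyl but also a different ether partner, so its value alone cannot isolate the methyl. For compound 4 the step expected is a 1.3-fold lower number from compound 2 to compound 4 (0.12 log units; within the scatter), within the scatter. Compound 4 is therefore estimated at 70000 nM, between 25000 nM and 200000 nM.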

Compound 4, half-maximal cytotoxic concentration: 13800 nM
Beside the measured number, compound 4's estimate is 5.1-fold (0.71 log units) above it, and the stated range ends above it.
By their numbers in this assay, from the lowest: compound 3; then compound 4; then compound 2. At a limit, above all of these: compound 1.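

In this assay, methyl in place of hydrogen on the aromatic carbon next to the ring nitrogen is not a neutral change: a 6.8-fold lower number from compound 2 to compound 4 (0.83 log units; beyond the scatter). Less compound is tolerated once this methyl is present, a reading that no earlier matched pair could give for this position. Neither number in the step is a limit; the only limit shown lies elsewhere in the series: the limit of > 316000 nM in this assay, at which 1 of the 4 values shown sits.

Going by these compounds, whether the methyl has the same effect with other ether partners remains open. So does the outcome with an ethyl group or an amine at this position.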